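Sulfonyl substituent swap in the hepatocyte clearance series

A few compounds are considered here, and "the series" means these few. Any claim that something is new, unique, unknown or untested is made for them only; others in the source may bear on it.

For the measured compounds named here, in an ADME assay on cells (Hepatocyte, Rattus norvegicus) for metabolic stability (a higher number here means faster removal of the compound, a lower number slower removal), compound 2 `Cc1ccc2[nH]c(C(=O)N[C@H]3CN(S(=O)(=O)c4cn(C)nc4C)C[C@@H]3C(=O)NCCN(C)C)cc2c1` stands at the lowest of the two numbers so far, giving 4 uL/min; compound 1 `Cc1ccc2[nH]c(C(=O)N[C@H]3CN(S(=O)(=O)c4ccccc4)C[C@@H]3C(=O)NCCN(C)C)cc2c1` gives 16 uL/min. Going by the values given here, the only measured step is a 4.0-fold lower number from compound 1 to compound 2 (0.60 log units; beyond the scatter), which concerns the same sulfonyl position. Compound 3 `Cc1ccc2[nH]c(C(=O)N[C@H]3CN(S(=O)(=O)C4CCOCC4)C[C@@H]3C(=O)NCCN(C)C)cc2c1` differs from compound 2 by oxan-4-yl in place of 1,3-dimethyl-1H-pyrazol-4-yl on a sulfonyl sulfur. Among the compounds with values here, no measured step covers this particular exchange, so the direction is open; a step within the scatter is expected, a 1.3-fold higher number from compound 2 to compound 3 (0.10 log units; within the scatter). Compound 3 is therefore estimated at 5 uL/min, within a range of 2 uL/min to 12 uL/min.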

Compound 3, intrinsic clearance in a liver preparation (reported as CLH), per the amount of preparation that the assay uses: 4 uL/min
For compound 3 the middle estimate is 1.3-fold (0.10 log units) above the measured one; low and high end bracket the measured number.
By their numbers in this assay, from the lowest: compounds 2 and 3 (each within the scatter of the next); then compound 1.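

For this assay, oxan-4-yl in place of 1,3-dimethyl-1H-pyrazol-4-yl gives no change at the digits printed from compound 2 to compound 3 (within the scatter), so a six-membered non-aromatic ring on the sulfonyl sulfur sits level with the five-membered aromatic one. Oxan-4-yl in place of phenyl gives a 4.0-fold lower number from compound 1 to compound 3 (0.60 log units; beyond the scatter), so the lower number seen with the pyrazole is not tied to an aromatic ring at this position. As far as these compounds go, whether an open-chain group such as methyl or a ring bearing an amine or carboxylic acid on the sulfonyl sulfur stays at this level remains open. Nothing on hand explains the pattern across these three compounds.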